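Acyl change from compound 3 to compound 4

The source may hold more compounds than are shown below. What is called first, only, known or untested is meant among the compounds shown, and "the series" means these compounds.

Values in a functional assay on MGC-803 cells (Homo sapiens) for inhibition, read by MTT assay, with a stated time of 48 h; a lower number here means a stronger inhibitor, a higher number a weaker inhibitor
compound 1 `COc1ccc(CN(C(=O)C=C(C)C)c2cc(OC)c(OC)c(OC)c2)cc1O` gives 320 nM
compound 2 `CC/C=C/C(=O)N(Cc1ccc(OC)c(O)c1)c1cc(OC)c(OC)c(OC)c1` gives 58 nM
compound 3 `COc1ccc(CN(C(=O)CCCl)c2cc(OC)c(OC)c(OC)c2)cc1O` gives 140 nM

Compound 3 gives 140 nM and holds the middle place among the three numbers. The next compound, not yet measured, is compound 4 `C/C=C/C(=O)N(Cc1ccc(OC)c(O)c1)c1cc(OC)c(OC)c(OC)c1` in the same assay. The change is prop-1-en-1-yl in place of 2-chloroethyl on a carbonyl carbon. The closest measured step is a 2.4-fold higher number from compound 2 to compound 3 (0.38 log units; beyond the scatter) for 2-chloroethyl in place of but-1-en-1-yl, and the change at hand runs the opposite way, from 2-chloroethyl to an unbranched alkenyl group. Not every alkenyl group points the same way, however. The step of a 2.3-fold lower number from compound 1 to compound 3 (0.36 log units; beyond the scatter) favours 2-chloroethyl over 2-methylprop-1-en-1-yl, and a 5.5-fold lower number from compound 1 to compound 2 (0.74 log units; beyond the scatter) separates the two alkenyl groups themselves. All three steps are modest, so a modest move towards a lower number is expected in this assay rather than a large one. The estimate is a 2.2-fold lower number from compound 3 to compound 4 (0.33 log units; beyond the scatter) as the expected step. For compound 4 the estimated value is 65 nM with an expected range from 25 nM to 170 nM on present evidence.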

Compound 4, half-maximal inhibitory concentration: 27 nM
Compound 4: the middle estimate sits 2.4-fold (0.38 log units) above what was measured; the measured number falls inside the stated range.
By their numbers in this assay, from the lowest: compound 4; then compound 2; then compound 3; then compound 1.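

In this assay, within the data shown here, the prop-1-en-1-yl group on the carbonyl carbon gives the strongest inhibitor of the four, with a 5.2-fold lower number from compound 3 to compound 4 (0.71 log units; beyond the scatter) against the 2-chloroethyl group and a 12-fold lower number from compound 1 to compound 4 (1.07 log units; beyond the scatter) against the 2-methylprop-1-en-1-yl group, the only large step so far. Trimming the unbranched alkenyl chain still pays, as a 2.1-fold lower number from compound 2 to compound 4 (0.33 log units; beyond the scatter) shows, so but-1-en-1-yl was not the best group at this position, and the three alkenyl groups now rank prop-1-en-1-yl, but-1-en-1-yl, 2-methylprop-1-en-1-yl from lowest number to highest, with 2-chloroethyl falling inside that alkenyl order rather than outside it. Nothing available explains these differences.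

The compounds shown leave open whether the double bond itself matters, as a saturated propyl group on this carbonyl carbon does not appear among them. They also leave open whether the trend carries on to a still shorter ethenyl group, and whether an amine at the end of the chain would be tolerated at this position.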